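Extending the benzylic methyl of compound 3 with a dimethylaminopyrrolidine

This account rests on a few compounds, and the source may have more. Where it says the series, first, only, none or still open, it means among the compounds named here.

The set contains three measured compounds. Compound 1 `Cc1ccc(NC(=O)c2ccc(CN3CCC(N(C)C)C3)c(C(F)(F)F)c2)cc1N1Cc2cnc(Nc3cnn(C)c3)nc2N(C)C1=O` in an ADME assay on BaF3 cells (Mus musculus) for inhibition, read by CellTiter-Glo, with a stated time of 72 h (on this read-out lower numbers stand for stronger inhibition of growth and higher numbers for weaker inhibition of growth), gives 414 nM, compound 2 `CC(=O)N1CCN(c2ccc(Nc3ncc4c(n3)N(C)C(=O)N(c3cc(NC(=O)c5ccc(CN6CCC(N(C)C)C6)c(C(F)(F)F)c5)ccc3C)C4)cn2)CC1` gives 187 nM, and compound 3 `Cc1ccc(Nc2ncc3c(n2)N(C)C(=O)N(c2cc(NC(=O)c4ccc(C)c(C(F)(F)F)c4)ccc2C)C3)cn1` gives 870 nM. Compound 3 therefore stands at the highest number of the three; compound 1 lies nearest to it and compound 2 furthest, both gaps beyond the scatter.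

Compound 4 `Cc1ccc(Nc2ncc3c(n2)N(C)C(=O)N(c2cc(NC(=O)c4ccc(CN5CCC(N(C)C)C5)c(C(F)(F)F)c4)ccc2C)C3)cn1` is reached from compound 3 by a single change: 3-(dimethylamino)pyrrolidin-1-yl in place of hydrogen on a saturated chain carbon bound to an aromatic carbon. Within the data shown here, no measured pair in this set isolates that change, so only the values of compound 1 and compound 2, which both carry the same group and give lower numbers but also differ from compound 3 elsewhere, offer any guide.

He expects a moderate downward step a 2.9-fold lower number from compound 3 to compound 4 (0.46 log units; beyond the scatter), clearly beyond the scatter, with a wide uncertainty. Compound 4 is accordingly estimated at 300 nM, within a range from 100 nM to 900 nM.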

Compound 4, concentration for 50% growth inhibition: 636 nM
Estimate against measurement, compound 4: 2.1-fold (0.33 log units) below, and the stated range covers the measured number.
By their numbers in this assay, from the lowest: compound 2; then compounds 1, 4 and 3 (each within the scatter of the next, the first and the last beyond it).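

In this assay, 3-(dimethylamino)pyrrolidin-1-yl in place of hydrogen on a saturated chain carbon bound to an aromatic carbon gives a 1.4-fold lower number from compound 3 to compound 4 (0.14 log units; within the scatter) on this read-out, so this change alone does not separate the two compounds. Among these compounds, exchanging the group on a nitrogen on an aromatic ring, 6-methylpyridin-3-yl for 1-methyl-1H-pyrazol-4-yl, gives a 1.5-fold higher number from compound 1 to compound 4 (0.19 log units; within the scatter) and likewise does not separate them, whereas methyl in place of 4-acetylpiperazin-1-yl on an aromatic carbon gives a 3.4-fold higher number from compound 2 to compound 4 (0.53 log units; beyond the scatter) and is the only one of these steps beyond the scatter. Nothing measured here accounts for any of these steps.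

From the compounds shown here alone, whether a morpholine or a primary amine in place of 3-(dimethylamino)pyrrolidin-1-yl would change the number remains open. Also open, going by these compounds, is whether 4-acetylpiperazin-1-yl gives a similar step in a compound that keeps the plain methyl of compound 3.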